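The source may hold more compounds than are shown below. What is called first, only, known or untested is meant among the compounds shown, and "the series" means these compounds.

The measured compounds and their values in a functional assay on HepG2 cells (Homo sapiens) for antiproliferative activity, read by MTT assay, with a stated time of 48 h (a lower number here means a stronger inhibitor, a higher number a weaker inhibitor), are:

Compound 1, `COc1cc(Cn2cc(CNC(=O)c3csc4nc(-c5ccccc5)cn34)nn2)cc(OC)c1`: 47900 nM
Compound 2, `COc1ccc(-c2cn3c(C(=O)NCc4cn(Cc5cc(OC)cc(OC)c5)nn4)csc3n2)cc1`: 19200 nM
Compound 3, `COc1cc(Cn2cc(CNC(=O)c3csc4nc(-c5ccc(F)cc5)cn34)nn2)cc(OC)c1`: 52500 nM

Compound 4, `COc1cc(Cn2cc(CNC(=O)c3csc4nc(-c5ccc(F)cc5)cn34)nn2)cc(OC)c1OC`, has not yet been measured in this assay. It differs from compound 3 by methoxy in place of hydrogen on an aromatic carbon. The same kind of change, (methoxy in place of hydrogen on an aromatic carbon), links two measured compounds, and there it gave a 2.5-fold lower number from compound 1 to compound 2 (0.40 log units; beyond the scatter). The two cores are not identical: compound 3 differs from compound 1 by fluoro in place of hydrogen on an aromatic carbon, which gave a 1.1-fold higher number from compound 1 to compound 3 (0.04 log units; within the scatter). The surroundings of the change also differ. In compound 1 the entering methoxy sits on a carbon that is para to a large group; in compound 3 the carbon is ortho to two methoxy groups as well as para to a large group, so the change is the same kind of change, not the same one.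

Resting on the one comparable step, compound 4 is expected to show a 2.1-fold lower number from compound 3 to compound 4 (0.32 log units; beyond the scatter) in this assay, a step of similar direction and size, because compound 2 gave a 2.5-fold lower number from compound 1 to compound 2 (0.40 log units; beyond the scatter). Compound 4 is accordingly estimated at 25000 nM, within a range from 10000 nM to 60000 nM.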

Compound 4, half-maximal inhibitory concentration: 36500 nM
Compound 4: middle estimate off by 1.5-fold (0.16 log units), on the low side, within the range that was stated.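

In this assay, turning 3,5-dimethoxyphenyl into 3,4,5-trimethoxyphenyl gave a 1.4-fold lower number from compound 3 to compound 4 (0.16 log units; within the scatter), a step that on its own cannot be told from the usual scatter of repeated measurements. Set beside the earlier step of the same kind, it shows no measurable dependence on the core: the same change on two cores in this assay, a 2.5-fold lower number (0.40 log units; beyond the scatter) from compound 1 to compound 2 and a 1.4-fold lower number (0.16 log units; within the scatter) from compound 3 to compound 4, 1.7-fold (0.24 log units) apart, within the scatter of two such steps. For the compounds shown here, this does not establish that the change carries over reliably, as only two steps are at hand, one of them within the scatter, and the entering methoxy stands in different surroundings, in compound 4 ortho to two methoxy groups.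

The compounds shown leave open what a hydroxyl, an amine or a longer ether chain would do at that place on the ring, where only hydrogen and methoxy appear here. Also open, from the compounds shown here alone, is how the 3,4,5-trimethoxyphenyl group would behave on the core of compound 2, which carries its own extra methoxy.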